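A few compounds are considered here, and "the series" means these few. Any claim that something is new, unique, unknown or untested is made for them only; others in the source may bear on it.

Measured compounds in a functional assay on B16-F10 cells (Mus musculus) for antiproliferative activity, read by ELISA and MTT assay, with a stated time of 48 h; a lower number here means a stronger inhibitor, a higher number a weaker inhibitor:
- compound 1, `O=C(/C=C/c1ccccc1)NS(=O)(=O)c1ccccc1`: 3.5 ug/mL
- compound 2, `O=C(/C=C/c1ccc(Cl)cc1)NS(=O)(=O)c1ccccc1`: 2.2 ug/mL
- compound 3, `O=C(/C=C/c1ccc(Cl)cc1)NS(=O)(=O)c1ccc(F)cc1`: 2 ug/mL

Compound 2 sits among the three measured numbers with no separation that the assay can resolve: the step of a 1.6-fold lower number from compound 1 to compound 2 (0.20 log units; within the scatter) and the step of a 1.1-fold lower number from compound 2 to compound 3 (0.04 log units; within the scatter) are both within the scatter, so none of the three compounds can be called stronger or weaker than another on this evidence.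

Compound 4, `CN(C)c1ccc(/C=C/C(=O)NS(=O)(=O)c2ccccc2)cc1`, has not yet been measured in this assay. It differs from compound 2 by dimethylamino in place of chloro on an aromatic carbon. Among the compounds with values here, no measured pair shows this exchange: the only change at that position is chloro in place of hydrogen, a 1.6-fold lower number from compound 1 to compound 2 (0.20 log units; within the scatter), which stayed within the scatter, and the change on the other ring, a 1.1-fold lower number from compound 2 to compound 3 (0.04 log units; within the scatter), is unrelated to the entering group. Within the data shown here, there is therefore no measured step that predicts a shift beyond the scatter in this assay in either direction, and a broad range must be allowed for an exchange that has not been tested.

Compound 4 is accordingly estimated at 2.5 ug/mL, with a range from 1 ug/mL to 6 ug/mL. For compound 4 this estimate implies the step of a 1.1-fold higher number from compound 2 to compound 4 (0.06 log units; within the scatter), which is expected to lie within the scatter.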

Compound 4, half-maximal inhibitory concentration: 2.3 ug/mL
Estimate against measurement, compound 4: 1.1-fold (0.04 log units) above; measured number inside the range.
By their numbers in this assay, from the lowest: compounds 3, 2, 4 and 1 (each within the scatter of the next).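

In this assay, the exchange at this position, para to a large group, replaces a single chlorine with dimethylamino, a group of three heavy atoms carrying one hydrogen-bond acceptor, and gives a small step (a 1.0-fold higher number from compound 2 to compound 4 (0.02 log units; within the scatter)). Measured against hydrogen at the same place, the group gives a step of similar standing (a 1.5-fold lower number from compound 1 to compound 4 (0.18 log units; within the scatter)), so hydrogen, chloro and dimethylamino cannot be told apart here, and the position now accepts a larger entering group with no shift that this assay can resolve. No available measurement bears on why the number stays within the scatter across these groups.

It remains open whether any group at this position can move the number beyond the scatter, and a carboxylic acid, a primary amine or a longer alkoxy chain there would test this more sharply than the groups shown. Going by these compounds, on the other ring, only fluoro and hydrogen appear, so the response to a larger group such as methoxy or trifluoromethyl on that ring also remains unknown, as does whether it would add to a change at the first position.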